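Ester Variation on the Carbonyl Oxygen: Compound 4

The source may hold more compounds than are shown below. What is called first, only, known or untested is meant among the compounds shown, and "the series" means these compounds.

Of the compounds shown here, three built on one shared core have been tested in an assay on membranes from HeLa cells for displacement of a labelled ligand from adenosine receptor A3 (Homo sapiens), read by scintillation counting, with a stated time of 180 min, tested at 1 uM; a higher number here means more inhibition at the concentration tested (going by the name of the read-out), a lower number less inhibition. Compound 1 `CC1=C(C(=O)NC(C)C)C(c2cccs2)NC(=O)N1` gives 1% there. Compound 2 `CC1=C(C(=O)SC(C)C)C(c2cccs2)NC(=O)N1` gives 1% in this assay. Compound 3 `CC1=C(C(=O)OC2CCCCC2)C(c2cccs2)NC(=O)N1` gives 1% in this assay, so compound 3 stands level with compounds 1 and 2. The steps between the three, no change at the digits printed from compound 1 to compound 2 (within the scatter), no change at the digits printed from compound 1 to compound 3 (within the scatter) and no change at the digits printed from compound 2 to compound 3 (within the scatter), all fall within the scatter: exchanging the group on the carbonyl carbon has moved nothing in this assay.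

Compound 4 `CC1=C(C(=O)OCC2CCC2)C(c2cccs2)NC(=O)N1` differs from compound 3 only in the group on the oxygen: cyclobutylmethyl in place of cyclohexyl on an oxygen next to a carbonyl group. The measured steps that bear on this position are the two leading to compound 3, and both were flat. Because no change at the digits printed from compound 1 to compound 3 (within the scatter) and no change at the digits printed from compound 2 to compound 3 (within the scatter) showed no movement, compound 4 is expected to remain at the same level, with an estimated step of a number 1 percentage points higher from compound 3 to compound 4 (within the scatter). For compound 4 the inhibition in this assay is estimated at 2%, within a range from 0% to 12%.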

Compound 4, a percentage reported as inhibition, at one concentration (the size of the read-out at that concentration, not a potency): 1%
Beside the measured number, compound 4's estimate is 1 percentage points above it, and the stated range covers the measured number.
By their numbers in this assay, from the lowest: compounds 1, 2, 3 and 4 (each within the scatter of the next).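

In this assay, the change within the ester group itself, cyclobutylmethyl in place of cyclohexyl on an oxygen next to a carbonyl group, shows no change at the digits printed from compound 3 to compound 4 (within the scatter). So replacing the six-membered carbon ring with a four-membered one carried on a methylene, a change of one carbon in the group, leaves the reading where it was, and the flat picture now extends from the group on the carbonyl carbon to the group on the oxygen. Cyclobutylmethoxy on the carbonyl carbon likewise shows no change at the digits printed from compound 2 to compound 4 (within the scatter) and no change at the digits printed from compound 1 to compound 4 (within the scatter), and no supporting evidence is available to account for this flatness.

The compounds shown leave open whether a carboxylic acid or a basic amine on the carbonyl carbon, or a longer chain or a phenyl ring on the oxygen, would move the reading. They also leave open whether any group at this position can raise the inhibition when all four compounds read this low.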